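Carbamate ester variation on a shared selenocyanate core

This account rests on a few compounds, and the source may have more. Where it says the series, first, only, none or still open, it means among the compounds named here.

Compound 1 `N#C[Se]c1ccc(NC(=O)OCc2ccccc2)cc1` gives 3700 nM in a functional assay on PC-3 cells (Homo sapiens) for cytotoxicity, read by MTT assay, with a stated time of 72 h; a higher number here means a weaker inhibitor of growth, a lower number a stronger inhibitor of growth.
Compound 2 `CCOC(=O)Nc1ccc([Se]C#N)cc1` gives 9900 nM in this assay.
Compound 3 `N#C[Se]c1ccc(NC(=O)Oc2ccccc2)cc1` gives 9100 nM in this assay.

Compound 3 stands second highest of the three numbers in this assay. Its nearest neighbour is compound 2, and the two lie within the scatter of each other: a 1.1-fold lower number from compound 2 to compound 3 (0.04 log units; within the scatter). Compound 1 is the furthest away, with a lower number than compound 3.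

Compound 4 `CCCCOC(=O)Nc1ccc([Se]C#N)cc1` has not yet been measured. It differs from compound 3 in one place: butyl in place of phenyl on an oxygen next to a carbonyl group. For the measured compounds named here, no measured step shows exactly this change. The closest comparison is compound 2 against compound 3, where an ethyl chain and a phenyl on the same oxygen give numbers within the scatter of each other. Going by the values given here, the only step that was beyond the scatter, a 2.7-fold higher number from compound 1 to compound 2 (0.43 log units; beyond the scatter), concerns a change on a saturated chain carbon and speaks less directly to the present change.

Compound 4 is therefore expected to show a step that stays within, or only just beyond, the scatter: a 1.3-fold lower number from compound 3 to compound 4 (0.11 log units; within the scatter). Compound 4 is estimated at 7000 nM, with a range from 3000 nM to 16000 nM.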

Compound 4, concentration for 50% growth inhibition in the PC-3 assay: 12400 nM
Compound 4: middle estimate off by 1.8-fold (0.25 log units), on the low side, within the range that was stated.
By their numbers in the PC-3 assay, from the lowest: compound 1; then compounds 3, 2 and 4 (each within the scatter of the next).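

In the PC-3 assay a butyl on this oxygen cannot be told apart from a phenyl (a 1.4-fold higher number from compound 3 to compound 4 (0.13 log units; within the scatter)) or from an ethyl (a 1.3-fold higher number from compound 2 to compound 4 (0.10 log units; within the scatter)), so among these three compounds neither a ring nor a longer chain at this place shows an effect, while compound 1 with its phenyl on a saturated chain carbon stays clearly apart (a 3.4-fold higher number from compound 1 to compound 4 (0.53 log units; beyond the scatter)). In a physicochemical assay, with a stated time of 6 min, tested at 0.1 mg/mL (on this read-out lower numbers stand for less inhibition and higher numbers for more inhibition at the one concentration tested (going by the name of the read-out)), compound 3 gives > 25% which is a limit of the assay and not a number: the limit of > 25% in the physicochemical assay, at which 1 of the 2 values shown sits. In the physicochemical assay compound 4 gives 12.6% and here the same change does separate the pair (a number at least 12.4 percentage points lower from compound 3 to compound 4 (beyond the scatter)), so a swap that is silent in the cell assay is not silent in every read-out.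

Compound 1 alone carries a phenyl on a saturated chain carbon, so one compound is all that supports its lower number in the PC-3 assay. From the compounds shown here alone, whether a chain longer than butyl, or a chain ending in an amine or a carboxylic acid, would shift the number at this oxygen remains open.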